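Chloro in place of cyclopropyl on compound 2

The source may hold more compounds than are shown below. What is called first, only, known or untested is meant among the compounds shown, and "the series" means these compounds.

- compound 1 `N#Cc1cc(C(=O)N2CCc3ccccc32)cc(I)c1O` gives 15200 nM
- compound 2 `N#Cc1cc(C(=O)N2CS(=O)(=O)c3ccccc32)cc(C2CC2)c1O` gives 10800 nM

In an ADME assay on the whole organism (Rattus norvegicus) for pharmacokinetics, read by HPLC, at a dose of 3 mg/kg by the oral route (on this read-out lower numbers stand for lower exposure and higher numbers for higher exposure at the dose given), compound 2 gives 10800 nM and compound 1 gives 15200 nM, so the two stand within the usual scatter of each other. Compound 3 `N#Cc1cc(C(=O)N2CS(=O)(=O)c3ccccc32)cc(Cl)c1O` keeps the core of compound 2 but has chloro in place of cyclopropyl on an aromatic carbon. Going by the values given here, no measured pair shows this change alone, so the forecast rests on those two close values. The expected move, a 1.1-fold lower number from compound 2 to compound 3 (0.03 log units; within the scatter), is none beyond the scatter. For compound 3 the estimated value in this assay is 10000 nM, with 4000 nM to 25000 nM as the expected range.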

Compound 3, maximal plasma concentration: 3870 nM
Compound 3: the middle estimate sits 2.6-fold (0.41 log units) above what was measured, outside the stated range (below it).
By their numbers in this assay, from the lowest: compound 3; then compounds 2 and 1 (each within the scatter of the next).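

At this position, ortho to a hydroxy group, the group on the ring can change the result in this assay: replacing cyclopropyl with chloro gives a 2.8-fold lower number from compound 2 to compound 3 (0.45 log units; beyond the scatter) and is the only single-place change shown here. Compounds 1 and 2 differ in more than one place, so they could not isolate this position. No measurement shown here accounts for the change.

Going by these compounds, whether a methyl or methoxy group at this position would give a number closer to that of chloro or cyclopropyl remains open. So does whether the same exchange would have a similar effect on the core of compound 1.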